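Swapping Trifluoromethyl for Fluoro in a Sulfonamide

The compounds below may be only part of what the source reports. "The series", "measured", "known", "first", "only" and "open" are said of these compounds alone.

Compound 1 `O=S(=O)(Nc1ccc2oc(-c3ccccc3)nc2c1)c1ccccc1C(F)(F)F` carries a trifluoromethyl group on a six-membered aromatic ring of carbon only. In an assay on cells for inhibition of HSP60/HSP10 (Homo sapiens), with a stated time of 60 min (a lower number here means a stronger inhibitor, a higher number a weaker inhibitor), compound 1 gives > 100000 nM, which is a limit of the assay and not a measured number (the limit of > 100000 nM in this assay, at which 1 of the 3 values shown sits). Two related compounds were measured as well. Compound 2 `O=S(=O)(Nc1ccc(-c2nc3ccccc3o2)cc1)c1cccc(C(F)(F)F)c1` gives 57000 nM in this assay. Compound 3 `O=S(=O)(Nc1ccc(-c2nc3cc(NS(=O)(=O)c4ccc(O)cc4)ccc3o2)cc1)c1ccc(O)cc1` gives 14000 nM in this assay. No two of these three compounds differ in one place only, so no single structural change has been measured on its own.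

Compound 4 `O=S(=O)(Nc1ccc2oc(-c3ccccc3)nc2c1)c1ccccc1F` is the untested partner of compound 1. Between them (fluoro in place of trifluoromethyl on an aromatic carbon). For the measured compounds named here, nothing among the measured compounds shows how this change bears on potency. Given that compound 1 sits at the limit of > 100000 nM in this assay, at which 1 of the 3 values shown sits, the step of a number no higher from compound 1 to compound 4 (the limit leaves the size open) is expected to amount to little, none beyond the scatter. Compound 4 is therefore estimated to give 100000 nM in this assay, with a range from 30000 nM to 300000 nM.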

Compound 4, half-maximal inhibitory concentration: > 100000 nM
Compound 4 gave a limit, no number; the forecaster's own chance of this, stated with the estimate: 70%; the middle value lies on the limit itself.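

Compound 1 and compound 4 both end at a limit of the assay and not at a number, so the step between them cannot be read: the limit of > 100000 nM in this assay, at which 2 of the 4 values shown sit.

The compounds shown leave open whether fluoro in place of trifluoromethyl changes the result in this assay at all.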